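Swapping chloro for methoxy on an anti-inflammatory chalcone amide

The source may report more compounds than this note shows. Statements on the series, on what has been measured and on what is new or still open speak of the compounds shown alone.

Measured so far:
Compound 1, `CC(O[N+](=O)[O-])C(=O)Nc1ccc(C(=O)/C=C/c2ccc(Cl)cc2)cc1`: 55%
Compound 2, `O=C(COCc1c(-c2ccccc2)no[n+]1[O-])Nc1ccc(C(=O)/C=C/c2ccc(Cl)cc2)cc1`: 48%

Both compounds were tested in a functional assay on the whole organism (strain albino) for inhibition, with Rattus norvegicus as the target, read by paw edema, with stated times of 30 min and 2 h, at a dose of 100 mg/kg by the oral route; on this read-out lower numbers stand for less inhibition and higher numbers for more inhibition at the one dose given (going by the name of the read-out). Compound 1 gives 55%, and compound 2 gives 48%. The two numbers sit close together, and the gap between them lies within the usual scatter of repeated measurements, so the inhibition in this assay can only be called level between the two on this evidence.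

Compound 3, `COc1ccc(/C=C/C(=O)c2ccc(NC(=O)COCc3c(-c4ccccc4)no[n+]3[O-])cc2)cc1`, has not yet been measured. It differs from compound 2 in one place: methoxy in place of chloro on an aromatic carbon. The rest of the shared core, including the amide-linked side chain, stays the same.

Among the compounds with values here, no measured pair shows this particular change, so there is nothing to lean on beyond the two numbers above. The expectation is a step no larger than the scatter in either direction, a number 3 percentage points lower from compound 2 to compound 3 (within the scatter). Compound 3 is therefore estimated at 45%, with a range from 30% to 60%.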

Compound 3, a percentage reported as inhibition, in the whole organism at one dose (the size of the read-out at that dose, not a potency): 42%
The estimate for compound 3 lay 3 percentage points above the measured number; measured number inside the range.
By their numbers in this assay, from the lowest: compounds 3, 2 and 1 (each within the scatter of the next, the first and the last beyond it).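

In this assay, methoxy in place of chloro on an aromatic carbon para to a large group gives a number 6 percentage points lower from compound 2 to compound 3 (within the scatter) and so leaves compound 2 and compound 3 level. Within the data shown here, this is the first direct test of this position, and it shows that at this one dose chloro, with 1 heavy atom and 0 hydrogen-bond acceptors, and methoxy, with 2 heavy atoms and 1 hydrogen-bond acceptor, cannot be told apart. No measurement at hand bears on what lies behind this result.

An amine or a carboxylic acid on this same aromatic carbon might or might not read differently from chloro and methoxy. As far as these compounds go, whether the same change gives a similar step on the side chain of compound 1 also remains open.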